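The source may hold more compounds than are shown below. What is called first, only, known or untested is meant among the compounds shown, and "the series" means these compounds.

Compound 1: `ClCc1ccc(Cn2cnc3c(Cl)ncnc32)cc1`, 30900 nM. Compound 2: `ClCc1ccccc1Cn1cnc2c(Cl)nc(Cl)nc21`, 3310 nM.

In a functional assay on SK-MEL-28 cells (Homo sapiens) for cytotoxicity, read by sulforhodamine B assay, with a stated time of 48 h (on this read-out lower numbers stand for stronger inhibition of growth and higher numbers for weaker inhibition of growth), compound 2 stands lowest of the two numbers; compound 1 gives the higher one, and that gap lies beyond the usual scatter. Compound 3, `ClCc1ccccc1Cn1cnc2c(Cl)ncnc21`, is not yet measured. It differs from compound 2 in one place: hydrogen in place of chloro on an aromatic carbon. For the measured compounds named here, no measured pair shows this change on its own, so its size is open; a moderate rise in the number, beyond the scatter, seems the more likely direction. Compound 3 is therefore expected to give 9000 nM, within 3000 nM to 30000 nM, a step of a 2.7-fold higher number from compound 2 to compound 3 (0.43 log units; beyond the scatter).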

Compound 3, concentration for total growth inhibition: 5490 nM
Beside the measured number, compound 3's estimate is 1.6-fold (0.21 log units) above it; the range from low to high includes it.
By their numbers in this assay, from the lowest: compounds 2 and 3 (each within the scatter of the next); then compound 1.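

In this assay putting hydrogen in place of chloro on the aromatic carbon between two ring nitrogen atoms gives a 1.7-fold higher number from compound 2 to compound 3 (0.22 log units; within the scatter) and so leaves the two compounds indistinguishable on this read-out. At this position, then, the chloro group is not needed to keep growth inhibition at this level, and hydrogen serves equally well. No measurement shown here offers an explanation for this result. Going by these compounds, whether an amine or a methoxy group on this same carbon would keep the number in this range remains open.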